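A Phenyl Ester in Place of a Trifluoroethyl Ester

A few compounds are considered here, and "the series" means these few. Any claim that something is new, unique, unknown or untested is made for them only; others in the source may bear on it.

Compound 1 `O=C(OCC(F)(F)F)c1ccsc1NC(=O)[C@@H]1CCCN1`: > 250 ug/mL
Compound 2 `COC(=O)c1ccsc1NC(=O)[C@H]1CCCN1`: 95.8 ug/mL

In a toxicity assay on HUVEC cells (Homo sapiens) for inhibition (a higher number here means a weaker inhibitor of growth, a lower number a stronger inhibitor of growth), compound 1 gives > 250 ug/mL, which is a limit of the assay rather than a number. Compound 1 therefore sits at the limit of > 250 ug/mL in this assay, at which 1 of the 2 values shown sits. Compound 2 gives 95.8 ug/mL in this assay. Compound 3 `O=C(Oc1ccccc1)c1ccsc1NC(=O)[C@@H]1CCCN1` differs from compound 1 by phenyl in place of 2,2,2-trifluoroethyl on an oxygen next to a carbonyl group. Among the compounds with values here, no measured step joins these two compounds, and compound 1 is known only as a limit, so the direction of an at least 1.6-fold lower number from compound 1 to compound 3 (0.22 log units; that floor lies within the scatter) is expected to stay within the scatter. Compound 3 is expected to give about 150 ug/mL in this assay, with a range from 50 ug/mL to 400 ug/mL.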

Compound 3, concentration for 50% growth inhibition: > 250 ug/mL
Compound 3: only a limit was reported; the forecaster's own chance of this, stated with the estimate: 45%; at least 1.6-fold (0.22 log units) between middle value and limit.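

Compound 1 and compound 3 are both reported only as a limit of the assay, so no step can be read between them: the limit of > 250 ug/mL in this assay, at which 2 of the 3 values shown sit.

The compounds shown leave open whether phenyl in place of 2,2,2-trifluoroethyl changes the result at all in this assay.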